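Removing a methoxy group on two different cores

This account rests on a few compounds, and the source may have more. Where it says the series, first, only, none or still open, it means among the compounds named here.

Measured in a functional assay on LNCaP C4-2 cells (Homo sapiens) for inhibition, read by MTT assay, with a stated time of 48 h; on this read-out higher numbers stand for weaker inhibition and lower numbers for stronger inhibition:
compound 1 `COc1cc(C2=NOC(c3c[nH]c4ccccc34)C2)cc(OC)c1OC` — 5000 nM
compound 2 `COc1ccc(C2=NOC(c3c[nH]c4ccccc34)C2)cc1OC` — 65500 nM
compound 3 `COc1ccc2c(C3CC(c4ccncc4)=NO3)c[nH]c2c1` — 3500 nM

Compound 4 `c1ccc2c(C3CC(c4ccncc4)=NO3)c[nH]c2c1` has not yet been measured. It differs from compound 3 by hydrogen in place of methoxy on an aromatic carbon. The difference between the core of compound 3 and the core of compound 1 is not broken down here. The same kind of change, (hydrogen in place of methoxy on an aromatic carbon), was measured between compound 1 and compound 2, where it gave a 13-fold higher number from compound 1 to compound 2 (1.12 log units; beyond the scatter). The two places are not the same: in compound 1 the carbon is ortho to a methoxy group, meta to a large group and meta to a methoxy group, whereas in compound 3 it sits on a ring that is part of a fused or bridged system of two rings, meta to a fused ring and para to a fused ring. Compound 3 stands nearest to compound 1, within the scatter, and far from compound 2. In this assay, among the measured compounds shown here, compound 4 is expected to show a 2.9-fold higher number from compound 3 to compound 4 (0.46 log units; beyond the scatter), a smaller step than the earlier one because the single measured step of this kind is a 13-fold higher number from compound 1 to compound 2 (1.12 log units; beyond the scatter) at a different place. The estimate for compound 4 is 10000 nM, between 3000 nM and 40000 nM.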

Compound 4, half-maximal inhibitory concentration: 12800 nM
Estimate against measurement, compound 4: 1.3-fold (0.11 log units) below; low and high end bracket the measured number.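

In this assay, hydrogen in place of methoxy on the core of compound 3 gives a 3.7-fold higher number from compound 3 to compound 4 (0.56 log units; beyond the scatter) and thus points the same way as the step on the core of compound 1. The direction carries over from one core to the other, but the size does not: the same change on two cores in this assay, a 13-fold higher number (1.12 log units; beyond the scatter) from compound 1 to compound 2 and a 3.7-fold higher number (0.56 log units; beyond the scatter) from compound 3 to compound 4, 3.6-fold (0.55 log units) apart, beyond the scatter of two such steps

These two pairs show neither whether the core itself or the different place of the methoxy group on each core sets the size of the step, nor whether the same direction would hold on any further core in this series.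

The compounds shown leave open how other groups at this place on the core of compound 3 would read, such as a hydroxyl group, an amine or a fluorine atom. They also leave open whether a longer chain on the oxygen, such as ethoxy in place of methoxy, would keep the number of compound 3 or move it toward that of compound 4.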